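Ethyl chromenone series: ethoxy to isobutoxy beside bromomethyl

A few compounds are considered here, and "the series" means these few. Any claim that something is new, unique, unknown or untested is made for them only; others in the source may bear on it.

Compound 3 `CCOc1ccc2c(=O)cc(CC)oc2c1CBr` has been run in a functional assay on KBVIN cells (Homo sapiens) for antiproliferative activity, read by sulforhodamine B assay, with a stated time of 72 h (on this read-out lower numbers stand for stronger inhibition of growth and higher numbers for weaker inhibition of growth), where compound 3 gives only a limit of > 32100 nM and no number. Compound 3 thus stands at one of the two limits among the three values shown, namely (the limit of > 32100 nM in this assay, at which 1 of the 3 values shown sits). The other limit is the limit of > 31300 nM in this assay, at which 1 of the 3 values shown sits, held by compound 2 `CCc1cc(=O)c2ccc(OCc3cccc(C#N)c3)c(C)c2o1`, for which this assay reports > 31300 nM as a limit, not a number. Among the measured compounds shown here, compound 1 `COC(=O)c1cccc(CSc2ccc3c(C)cc(=O)oc3c2)c1` is the only one with a numerical value in this assay, giving 5410 nM.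

Compound 4 `CCc1cc(=O)c2ccc(OCC(C)C)c(CBr)c2o1` has not yet been measured in this assay. It differs from compound 3 by isopropyl in place of methyl on a saturated chain carbon bound to an oxygen on an aromatic ring. No step between two measured compounds is available, so the size of this change cannot be read from the numbers shown. The expectation is therefore no step beyond the usual scatter, written as a number no higher from compound 3 to compound 4 (the limit leaves the size open). Compound 4 is estimated at 32000 nM in this assay, within 10000 nM to 60000 nM, and is expected most likely to come back as a limit again.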

Compound 4, concentration for 50% growth inhibition: > 29400 nM
Compound 4: only a limit was reported; the forecaster's own chance of this, stated with the estimate: 70%; the middle value is on the limit's open side.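

Compound 3 and compound 4 both give only limits in this assay, so the step between them, ethoxy to isobutoxy, cannot be read. The compounds shown leave open whether this change on the shared core alters growth inhibition at all.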